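The source may hold more compounds than are shown below. What is called first, only, known or untested is meant among the compounds shown, and "the series" means these compounds.

In a functional assay on OVCAR-8 cells (Homo sapiens) for inhibition, read by sulforhodamine B assay, with a stated time of 48 h (on this read-out lower numbers stand for higher toxicity in this test and higher numbers for lower toxicity in this test), compound 1 `COc1cc2cc(Oc3ccc(NC(=O)Nc4cccc(C(F)(F)F)c4)cc3)c(C)nc2cc1OC` gives 19900 nM. Compound 2 `COc1cc2cc(Oc3ccc(NC(=O)Nc4ccc(Cl)c(C(F)(F)F)c4)cc3)c(C)nc2cc1OC` is reported in this test only as a limit, > 32500 nM. That boundary, (the limit of > 32500 nM in this assay, at which 1 of the 2 values shown sits), is as far as the test reaches. Among the compounds with values here, the single measured step, an at least 1.6-fold higher number from compound 1 to compound 2 (0.21 log units; that floor lies within the scatter), gives only a floor, and that floor lies within the scatter. Compound 3 `COc1cc2cc(Oc3ccc(NC(=O)Nc4ccc(Cl)c(Cl)c4)cc3)c(C)nc2cc1OC` differs from compound 2 by chloro in place of trifluoromethyl on an aromatic carbon. With one step of that size to go on, the change is expected to be an at least 1.0-fold lower number from compound 2 to compound 3 (0.03 log units; that floor lies within the scatter), nothing beyond the scatter. Compound 3 is therefore estimated at 30000 nM, between 10000 nM and 90000 nM.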

Compound 3, concentration lethal to 50% of the cells: 36000 nM
Compound 3: the middle estimate sits 1.2-fold (0.08 log units) below what was measured; low and high end bracket the measured number.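

Compound 3 gives this position a measured number with chloro in place of trifluoromethyl, something compound 2 could not provide. Compound 2 is reported only as a limit, so the step from it to compound 3 cannot be read: the limit of > 32500 nM in this assay, at which 1 of the 3 values shown sits.

What can be read in this assay is a 1.8-fold higher number from compound 1 to compound 3 (0.26 log units; within the scatter), so 3,4-dichlorophenyl and 3-(trifluoromethyl)phenyl cannot be told apart in this test.

The compounds shown leave open whether a different group on this aromatic carbon, such as an amine or a carboxylic acid, would give a step beyond the scatter.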